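Trifluoromethyl for Chloro: Clearance Outlook for Compound 3

This account rests on a few compounds, and the source may have more. Where it says the series, first, only, none or still open, it means among the compounds named here.

Of the compounds shown here, two sharing one core have been measured in an ADME assay on microsomes from liver (Mus musculus) for metabolic stability, read by LC-MS, using NADPH, tested at 1 uM; a lower number here means slower removal, a higher number faster removal of the compound. Compound 1 `N#Cc1cnc(NC(=O)CCCOc2cccc(Cl)c2)s1` gives 224 mL.min-1.g-1, and compound 2 `Cc1cnc(NC(=O)CCCOc2cccc(C#N)c2)s1` gives 460 mL.min-1.g-1. Compound 1 therefore holds the lower of the two numbers, and the gap between compound 1 and compound 2 lies beyond the usual scatter. For the measured compounds named here, these two compounds differ from each other in more than one place, so no single structural step separates them.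

Compound 3 `N#Cc1cnc(NC(=O)CCCOc2cccc(C(F)(F)F)c2)s1` differs from compound 1 in one place only: trifluoromethyl in place of chloro on an aromatic carbon. Going by the values given here, no measured pair shows this change, so the data give no direct guide to its effect. Without such a guide, the step from compound 1 to compound 3 is expected to stay within the scatter in either direction, and the estimated step is a 1.1-fold lower number from compound 1 to compound 3 (0.03 log units; within the scatter). Compound 3 is accordingly estimated at 210 mL.min-1.g-1, with a range from 100 mL.min-1.g-1 to 450 mL.min-1.g-1.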

Compound 3, intrinsic clearance in microsomes in the Mus musculus assay: 56 mL.min-1.g-1
Compound 3: the middle estimate sits 3.8-fold (0.57 log units) above what was measured; measured number below the stated range.
By their numbers in the Mus musculus assay, from the lowest: compound 3; then compound 1; then compound 2.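

In the Mus musculus assay, trifluoromethyl in place of chloro on an aromatic carbon, meta to a large group, gives a 4.0-fold lower number from compound 1 to compound 3 (0.60 log units; beyond the scatter), so this is the first single-place step shown, and it indicates that the group at this position can change the clearance read-out. In a physicochemical assay for solubility, read by nephelometry, at pH 2 (on this read-out lower numbers stand for lower solubility and higher numbers for higher solubility), compound 1 gives < 1600 nM, which is a limit of the assay and not a number. In the physicochemical assay compound 3 gives < 1600 nM, also a limit, so no step in solubility can be read: the limit of < 1600 nM in the physicochemical assay, at which 2 of the 2 values shown sit.

The compounds shown do not tell whether a bromo or a methoxy group on the same aromatic carbon would give a similar step. They also leave open whether the change from chloro to trifluoromethyl would give a similar step on a core bearing a methyl group in place of the nitrile.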